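Series notes: cyclohexyl in place of 2,4-dimethylphenyl on sulfur

This account rests on a few compounds, and the source may have more. Where it says the series, first, only, none or still open, it means among the compounds named here.

Of the compounds shown here, two of the shared core have been measured in a functional assay on U2OS cells (Homo sapiens) for antiproliferative activity, read by MTT assay, with a stated time of 72 h; on this read-out higher numbers stand for weaker inhibition and lower numbers for stronger inhibition. Compound 1 `O=C(CSc1nc2ccccc2[nH]1)Nc1ccc2nc(NC(=O)c3ccc(C(F)(F)F)cc3)sc2c1` gives 7110 nM in this assay. Compound 2 `Cc1ccc(SCC(=O)Nc2ccc3nc(NC(=O)c4ccc(C(F)(F)F)cc4)sc3c2)c(C)c1` gives 1000 nM in this assay. Among the measured compounds shown here, the one measured step, a 7.1-fold lower number from compound 1 to compound 2 (0.85 log units; beyond the scatter), shows that the group on the sulfur moves the read-out by a useful margin. For the measured compounds named here, compound 2 thus stands at the lowest of the two numbers, with compound 1 as its only neighbour at a higher number beyond the scatter.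

Compound 3 `O=C(CSC1CCCCC1)Nc1ccc2nc(NC(=O)c3ccc(C(F)(F)F)cc3)sc2c1` remains to be measured. It differs from compound 2 in one place: cyclohexyl in place of 2,4-dimethylphenyl on a sulfur. Going by the values given here, only the step from compound 1 to compound 2 touches this sulfur, and there one aromatic ring gave way to another; no measured pair shows an aromatic ring replaced by a non-aromatic one at this position, so the direction of the new step is not fixed by the data. On balance compound 3 is expected to give a somewhat higher number than compound 2, a 1.8-fold higher number from compound 2 to compound 3 (0.26 log units; within the scatter), a step that may lie within the scatter. The estimate for compound 3 in this assay is 1800 nM, with a range from 600 nM to 6000 nM.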

Compound 3, half-maximal inhibitory concentration: 12300 nM
For compound 3 the middle estimate is 6.8-fold (0.83 log units) below the measured one; measured number outside the range, above it.
By their numbers in this assay, from the lowest: compound 2; then compounds 1 and 3 (each within the scatter of the next).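

In this assay, the change from the aromatic 2,4-dimethylphenyl to the non-aromatic cyclohexyl on the sulfur gives a 12-fold higher number from compound 2 to compound 3 (1.09 log units; beyond the scatter), so this position also responds strongly to a swap of an aromatic ring for a non-aromatic one. The other new step, a 1.7-fold higher number from compound 1 to compound 3 (0.24 log units; within the scatter), places the groups of these two compounds within the scatter of each other, even though 1H-benzimidazol-2-yl is aromatic and cyclohexyl is not; among the three compounds, an aromatic ring on the sulfur is therefore not enough for the low number, and only compound 2 stands apart from the other two. Nothing available explains why 2,4-dimethylphenyl differs from the other two groups.

The compounds shown leave open whether the low number of compound 2 depends on its methyl groups, which a plain phenyl ring on the sulfur would test. They also leave open how an open carbon chain such as n-hexyl, or a chain ending in an amine or a carboxylic acid, would read at this position.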